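A few compounds are considered here, and "the series" means these few. Any claim that something is new, unique, unknown or untested is made for them only; others in the source may bear on it.

In a physicochemical assay for solubility, in phosphate buffer, at pH 7.4 (on this read-out higher numbers stand for higher solubility and lower numbers for lower solubility), three compounds sharing a core have been measured so far. Compound 1 (`CCOC(=O)c1c(-c2ccccc2C)[nH]c2cc(OC)ccc2c1=O`) gives > 100000 nM, which is a limit of the assay and not a number. Compound 2 (`CCOC(=O)c1c(-c2cccc(C)c2)[nH]c2cc(OC)ccc2c1=O`) gives 48000 nM and compound 3 (`CCOC(=O)c1c(-c2ccccc2Cl)[nH]c2cc(OC)ccc2c1=O`) gives 28000 nM. These two values lie within the scatter of each other (a 1.7-fold lower number from compound 2 to compound 3 (0.23 log units; within the scatter)), so compound 3 stands level with compound 2.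

The next step leads to compound 4 (`CCOC(=O)c1c(-c2ccc(Cl)c(Cl)c2)[nH]c2cc(OC)ccc2c1=O`), with 3,4-dichlorophenyl in place of 2-chlorophenyl on an aromatic carbon. Among the compounds with values here, no measured compound carries two chlorines, so only indirect guidance exists. Within the data shown here, two measured steps bear on this change, and both went to lower numbers beyond the scatter: one moved the methyl (an at least 2.0-fold lower number from compound 1 to compound 2 (0.31 log units; beyond the scatter)), and the other put chloro in place of methyl (an at least 3.5-fold lower number from compound 1 to compound 3 (0.55 log units; beyond the scatter)). From the compounds shown here alone, both start from a limit, so their full sizes are unknown. The 3,4-dichlorophenyl group combines both kinds of change, so a modest further drop is expected (a 3.1-fold lower number from compound 3 to compound 4 (0.49 log units; beyond the scatter)). For compound 4 the expected value is about 9000 nM (estimated range 2500 nM to 28000 nM).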

Compound 4, solubility: 17000 nM
Compound 4: the middle estimate sits 1.9-fold (0.28 log units) below what was measured; measured number inside the range.
By their numbers in this assay, from the lowest: compounds 4, 3 and 2 (each within the scatter of the next, the first and the last beyond it). At a limit, above all of these: compound 1.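

At this position, next to the ring nitrogen, 3,4-dichlorophenyl in place of 2-chlorophenyl gives no clear change in this assay: a 1.6-fold lower number from compound 3 to compound 4 (0.22 log units; within the scatter). Against 3-methylphenyl, the same group gives the first gap beyond the scatter between two compounds that both have a true number, with a 2.8-fold lower number from compound 2 to compound 4 (0.45 log units; beyond the scatter). Against 2-methylphenyl there is also a drop, with an at least 5.8-fold lower number from compound 1 to compound 4 (0.76 log units; beyond the scatter), but its full size stays unknown because compound 1 sits at a limit: the limit of > 100000 nM in this assay, at which 1 of the 4 values shown sits.

From the compounds shown here alone, all four compounds carry only methyl or chloro on this phenyl ring, so what an amine or a carboxylic acid there would do in this assay stays open. Also open, going by these compounds, is how 3-chlorophenyl or 4-chlorophenyl alone would compare with 3,4-dichlorophenyl.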